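Removing a methoxy group: compounds 1 to 4

A few compounds are considered here, and "the series" means these few. Any claim that something is new, unique, unknown or untested is made for them only; others in the source may bear on it.

Values so far in a functional assay on MDA-MB-231 cells (Homo sapiens) for antiproliferative activity, read by CCK-8 assay, with a stated time of 48 h; a lower number here means a stronger inhibitor, a higher number a weaker inhibitor:
compound 1 `Cc1[nH]c2ccccc2c1C1=C(Br)C(=O)C(c2c(C)[nH]c3ccccc23)=C(Br)C1=O`: 5.55 ug/mL
compound 2 `COc1ccc2[nH]c(C)c(C3=C(Br)C(=O)C(c4c(C)[nH]c5ccccc45)=C(Br)C3=O)c2c1`: a limit, > 10 ug/mL
compound 3 `COc1ccc2[nH]c(C)c(C3=C(Cl)C(=O)C(Cl)=C(c4c(-c5ccc(C)cc5)[nH]c5ccccc45)C3=O)c2c1`: 6.04 ug/mL

Compound 2 sits at the limit of > 10 ug/mL in this assay, at which 1 of the 3 values shown sits, so only a limit is known for it. Among the measured compounds shown here, the one counted change among the measured compounds, (hydrogen in place of methoxy on an aromatic carbon), gives an at least 1.8-fold lower number from compound 2 to compound 1 (0.25 log units; that floor lies within the scatter). Compound 1 and compound 3 lie within the scatter of each other, so no order between them is claimed. The difference between the core of compound 2 and the core of compound 3 is not broken down here.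

Compound 4 `Cc1ccc(-c2[nH]c3ccccc3c2C2=C(Cl)C(=O)C(Cl)=C(c3c(C)[nH]c4ccccc34)C2=O)cc1` is not yet measured. It relates to compound 3 as compound 1 relates to compound 2: hydrogen in place of methoxy on an aromatic carbon, the same change at the same kind of place. Resting on compound 2 and compound 1, where the step was an at least 1.8-fold lower number from compound 2 to compound 1 (0.25 log units; that floor lies within the scatter), a small downward step from compound 3 is expected, a 1.3-fold lower number from compound 3 to compound 4 (0.13 log units; within the scatter), though the floor of that earlier step lies within the scatter, so a flat result is also possible. Compound 4 is therefore estimated at 4.5 ug/mL, between 2 ug/mL and 10 ug/mL.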

Compound 4, half-maximal inhibitory concentration: 5.77 ug/mL
Compound 4: middle estimate off by 1.3-fold (0.11 log units), on the low side, within the range that was stated.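

Replacing methoxy with hydrogen on the core of compound 3 gives a 1.0-fold lower number from compound 3 to compound 4 (0.02 log units; within the scatter) in this assay, so on this core the change leaves no readable effect on the number. Among the compounds shown here, compound 2 has only a limit of > 10 ug/mL and not a number, so the first instance of the change gives a floor and no size. The results therefore do not show that the change carries from one core to the other with the same size, nor that it behaves differently on the two cores: the same change on two cores in this assay, an at least 1.8-fold lower number (0.25 log units; that floor lies within the scatter) from compound 2 to compound 1 and a 1.0-fold lower number (0.02 log units; within the scatter) from compound 3 to compound 4; the limit leaves it open whether they differ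

Still open, going by these compounds, is whether a different group at the same place, such as an amine, a carboxylic acid or a longer alkoxy chain, would move the number beyond the scatter on either core. For the compounds shown here, also open is whether hydrogen and methoxy would remain indistinguishable on further cores of this series, since the comparison rests on only two pairs of compounds.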